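The compounds below may be only part of what the source reports. "The series", "measured", "known", "first", "only" and "open" are said of these compounds alone.

Of the compounds shown here, three have so far been measured in a functional assay on BMDM cells (Mus musculus, strain C57BL/6) for inhibition, with a stated time of 2 days; a higher number here means a weaker inhibitor, a lower number a stronger inhibitor. Compound 1 `O=C(Cn1cc(-c2ccncc2)nn1)Nc1nccs1` gives 2 nM in this assay. Compound 3 `O=C(Cn1cc(-c2ccc(Cl)cc2)nn1)Nc1nccs1` gives 1100 nM in this assay, and compound 2 `CCOC(=O)c1sc(NC(=O)Cn2cc(-c3ccc(Cl)cc3)nn2)nc1C` gives 180 nM in this assay. Compound 3 and compound 1 share one core and differ in a single place: pyridin-4-yl in place of 4-chlorophenyl on an aromatic carbon. That one change brings a 550-fold lower number from compound 3 to compound 1 (2.74 log units; beyond the scatter), a large step. For the measured compounds named here, compound 2 and compound 3 carry different cores; how those cores differ is not broken down here, and their values show only that compound 2 sits at a lower number than compound 3, a gap beyond the scatter.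

Compound 4 `CCOC(=O)c1sc(NC(=O)Cn2cc(-c3ccncc3)nn2)nc1C` has not yet been measured. It is related to compound 2 by the same kind of change that turned compound 3 into compound 1: pyridin-4-yl in place of 4-chlorophenyl on an aromatic carbon. The surroundings are not identical, since in compound 2 the ring atom two bonds away bears a large group, while in compound 3 it bears a group of 9 heavy atoms. The step from compound 2 to compound 4 is expected to be a 120-fold lower number from compound 2 to compound 4 (2.08 log units; beyond the scatter), set beside a 550-fold lower number from compound 3 to compound 1 (2.74 log units; beyond the scatter); it rests on that single earlier step, and on a different core it is expected to come out somewhat smaller. Compound 4 is therefore estimated at 1.5 nM, between 0.3 nM and 8 nM.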

Compound 4, half-maximal inhibitory concentration: 120 nM
Compound 4: the middle estimate sits 80-fold (1.90 log units) below what was measured, and the stated range ends below it.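

In this assay, for the compounds shown here, pyridin-4-yl in place of 4-chlorophenyl on the core of compound 2 gives a 1.5-fold lower number from compound 2 to compound 4 (0.18 log units; within the scatter), so on this core the change leaves no step that can be told from the scatter. The large step seen on the core of compound 3 therefore did not carry over, and the same change cannot be assumed to act alike on both cores: the same change on two cores in this assay, a 550-fold lower number (2.74 log units; beyond the scatter) from compound 3 to compound 1 and a 1.5-fold lower number (0.18 log units; within the scatter) from compound 2 to compound 4, 370-fold (2.56 log units) apart, beyond the scatter of two such steps. This shows that the result of the change depends on the core, but with one pair on each core it gives no rule for other cores and does not show which feature of the core of compound 2 accounts for the difference.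

The compounds shown leave open which of the groups that set the core of compound 2 apart from the core of compound 3 matters. They also leave open how the change would fare on a core carrying a carboxylic acid or an amine in their place.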